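Methyl on the Anilino Ring: From Compound 3 to Compound 4

A few compounds are considered here, and "the series" means these few. Any claim that something is new, unique, unknown or untested is made for them only; others in the source may bear on it.

Compounds measured so far in a functional assay, with a stated time of 150 min, tested at 25 ug/mL; on this read-out lower numbers stand for a weaker effect and higher numbers for a stronger effect at the one concentration tested:
compound 1, `COC(=O)c1c(Nc2ccccc2)sc(C(=O)c2ccc(OC)cc2)c1C`, gives 36.9%;
compound 2, `COC(=O)c1c(Nc2ccc(C)cc2)sc(C(=O)c2ccc(OC)cc2)c1C`, is reported as "not active" (no number reported);
compound 3, `COc1ccc(C(=O)c2sc(Nc3ccccc3)c(C(=O)O)c2C)cc1`, gives 52.6%.

Among the two compounds with a number, compound 3 stands highest; its nearest neighbour is compound 1, and the only measured step, a number 15.7 percentage points higher from compound 1 to compound 3 (beyond the scatter), lies beyond the scatter. Compound 4, `COc1ccc(C(=O)c2sc(Nc3ccc(C)cc3)c(C(=O)O)c2C)cc1`, has not yet been measured. It differs from compound 3 by methyl in place of hydrogen on an aromatic carbon. For the measured compounds named here, no measured step covers this change directly. The closest comparison is the pair compound 1 and compound 2, which differ in the same way: in this assay compound 1 gives 36.9%, while compound 2 is reported as "not active" (no number reported). That comparison points downward, though it is a single pair and compound 2 carries no number. Compound 4 is therefore expected to fall below compound 3, with a step estimated at a number 37.6 percentage points lower from compound 3 to compound 4 (beyond the scatter). The estimate for compound 4 is 15%, ranging from 0% to 40%, with a real chance that only a report of no activity is given.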

Compound 4, a percentage reported as activity, at one concentration (the size of the read-out at that concentration, not a potency): "not active" (no number reported)
Nothing numeric was reported for compound 4, and the estimate cannot be compared.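

For the compounds shown here, compound 4 is reported only as "not active", without a number, so no step from compound 3 to compound 4 can be read. Nothing shown here offers an explanation for this result. The compounds shown leave open how large the effect of exchanging phenyl for 4-methylphenyl is.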